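Aryl to benzyl swap on the ring amine nitrogen

The source may hold more compounds than are shown below. What is called first, only, known or untested is meant among the compounds shown, and "the series" means these compounds.

Compound 1, `CCCn1c(=O)c2[nH]c(-c3ccc(S(=O)(=O)N4CCN(c5ccc(Cl)cc5)CC4)cc3)nc2n(CC)c1=O`: > 1000 nM in an assay on CHO cells for displacement of a labelled ligand from adenosine receptor A3 (Homo sapiens), read by scintillation counting, with a stated time of 45 min, in the presence of a further agent that is not named here; a higher number here means a weaker inhibitor, a lower number a stronger inhibitor
Compound 2, `CCCn1c(=O)c2[nH]c(-c3ccc(S(=O)(=O)N4CCN(c5ccc(Cl)cc5)CC4)cc3)nc2n(C)c1=O`: > 1000 nM in this assay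
Compound 3, `CCCn1c(=O)[nH]c2nc(-c3ccc(S(=O)(=O)N4CCN(c5ccc(Br)cc5)CC4)cc3)[nH]c2c1=O`: > 1000 nM in this assay

Each of these three values is a limit of the assay, not a number. Compound 3 therefore stands at the limit, as do the two others, (the limit of > 1000 nM in this assay, at which 3 of the 3 values shown sit). Among the compounds with values here, the only paired step, a step that the two limits leave unreadable from compound 1 to compound 2, is unreadable between two limits and gives no size.

Compound 4, `CCCn1c(=O)[nH]c2nc(-c3ccc(S(=O)(=O)N4CCN(Cc5ccc(Br)c(F)c5)CC4)cc3)[nH]c2c1=O`, differs from compound 3 by 4-bromo-3-fluorobenzyl in place of 4-bromophenyl on an amine nitrogen in a ring. Within the data shown here, no measured step bears on this change, so no direction or size can be drawn from the three compounds. Compound 4 is expected to show a step that the limit leaves unreadable from compound 3 to compound 4 in this assay, most likely remaining at the limit, with an estimated value of 2000 nM and a range from 300 nM to 15000 nM.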

Compound 4, inhibition constant: > 1000 nM
Compound 4 gave a limit, no number; the forecaster's own chance of this, stated with the estimate: 70%; the middle value does not contradict the limit.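

Compound 3 and compound 4 both sit at a limit, not a number, so no step can be read between them: the limit of > 1000 nM in this assay, at which 4 of the 4 values shown sit.

The compounds shown leave open whether 4-bromo-3-fluorobenzyl or 4-bromophenyl on an amine nitrogen in a ring gives the stronger inhibitor in this assay.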